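Hexyl extension on a macrolide side chain: lipophilicity

A few compounds are considered here, and "the series" means these few. Any claim that something is new, unique, unknown or untested is made for them only; others in the source may bear on it.

Measured so far:
Compound 1 `CCCCCCCC(=O)NCCCO[C@H]1[C@H](C)O[C@@H](O[C@H]2[C@H](C)[C@@H](O[C@@H]3O[C@H](C)C[C@H](N(C)C)[C@H]3O)[C@](C)(OC)C[C@@H](C)C(=O)[C@H](C)[C@@H](O)[C@](C)(O)[C@@H](CC)OC(=O)[C@@H]2C)C[C@@]1(C)OC` — 6.02
Compound 2 `CC[C@H]1OC(=O)[C@H](C)[C@@H](O[C@H]2C[C@@](C)(OC)[C@@H](O)[C@H](C)O2)[C@H](C)[C@@H](O[C@@H]2O[C@H](C)C[C@H](N(C)C)[C@H]2O)[C@](C)(OC)C[C@@H](C)C(=O)[C@H](C)[C@@H](OCCCNC(C)=O)[C@]1(C)O` — 2.72
Compound 3 `CC[C@H]1OC(=O)[C@H](C)[C@@H](O[C@H]2C[C@@](C)(OC)[C@@H](OCCCNC(C)=O)[C@H](C)O2)[C@H](C)[C@@H](O[C@@H]2O[C@H](C)C[C@H](N(C)C)[C@H]2O)[C@](C)(OC)C[C@@H](C)C(=O)[C@H](C)[C@@H](O)[C@]1(C)O` — 3.08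

Three compounds share a large macrolide-type core and carry the same amide-terminated side chain, attached at different points of the core. In a physicochemical assay for lipophilicity, read by HPLC, measured as chromatographic lipophilicity, at pH 7.4 (on this read-out lower numbers stand for lower lipophilicity and higher numbers for higher lipophilicity), compound 2 gives 2.72, the lowest of the three numbers; compound 3 gives 3.08 and compound 1 gives 6.02, both beyond the usual scatter from compound 2.

Compound 3 and compound 1 differ in one place: hexyl in place of hydrogen on a saturated chain carbon bound to a carbonyl carbon. This change gives a number 2.94 log units higher from compound 3 to compound 1 (beyond the scatter), a large step.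

Compound 2 and compound 3 are built from the same atoms joined differently; how their cores differ is not broken down here.

Compound 4 `CCCCCCCC(=O)NCCCO[C@@H]1[C@@H](C)C(=O)[C@H](C)C[C@@](C)(OC)[C@H](O[C@@H]2O[C@H](C)C[C@H](N(C)C)[C@H]2O)[C@@H](C)[C@H](O[C@H]2C[C@@](C)(OC)[C@@H](O)[C@H](C)O2)[C@@H](C)C(=O)O[C@H](CC)[C@@]1(C)O` has not yet been measured in this assay. It stands to compound 2 as compound 1 stands to compound 3: hexyl in place of hydrogen on a saturated chain carbon bound to a carbonyl carbon. The place of the change is described in the same words for both pairs, so it is the same change.

For the measured compounds named here, because the single measured example of this change, a number 2.94 log units higher from compound 3 to compound 1 (beyond the scatter), is large and well beyond the scatter, a step of similar size is expected for compound 4: a number 2.94 log units higher from compound 2 to compound 4 (beyond the scatter). Starting from compound 2, compound 4 is therefore estimated at 5.66, with a range from 5 to 6.3. This expectation rests on one pair only, so the actual step could deviate.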

Compound 4, distribution coefficient: 5.07
Compound 4: middle estimate off by 0.59 log units, on the high side, and the stated range covers the measured number.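

In this assay, putting hexyl in place of hydrogen on a saturated chain carbon bound to a carbonyl carbon gives a number 2.35 log units higher from compound 2 to compound 4 (beyond the scatter), and the same change in the earlier pair gave a number 2.94 log units higher from compound 3 to compound 1 (beyond the scatter). In both pairs, with the side chain attached at a different point of the core, the step is large and runs the same way, so the direction of the change carried over, but the two printed sizes are not identical, and two pairs do not establish a fixed size for this step or show that it would hold on any other core. Nothing measured here explains why the two sizes are not the same.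

The compounds shown hold only hydrogen or hexyl at this place, so what a shorter chain such as propyl, a longer chain such as decyl, or a chain ending in an amine or a carboxylic acid would give in this assay remains open. Also open, on these data alone, is whether the same change would give a comparable step with the side chain attached at a third point of the core.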